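Removing the Hydroxy Group from Compound 1

The source may report more compounds than this note shows. Statements on the series, on what has been measured and on what is new or still open speak of the compounds shown alone.

Compound 1 `COc1ccc(-c2cn(-c3ccc(OC(F)(F)F)cc3)nn2)cc1O`: > 10000 nM, a limit.
Compound 2 `COc1ccc(-n2cc(-c3ccc(OC)c(O)c3)nn2)cc1`: > 10000 nM, a limit.

In a functional assay on MDA-MB-231 cells (Homo sapiens) for cytotoxicity, read by MTT assay (a higher number here means a weaker inhibitor, a lower number a stronger inhibitor), compound 1 gives > 10000 nM, which is a limit of the assay and not a number. Between the two measured compounds lies a step that the two limits leave unreadable from compound 1 to compound 2, so no readable size can be taken from it. Both values sit at the limit of > 10000 nM in this assay, at which 2 of the 2 values shown sit. Compound 3 `COc1ccc(-c2cn(-c3ccc(OC(F)(F)F)cc3)nn2)cc1` differs from compound 1 by hydrogen in place of hydroxy on an aromatic carbon. For the measured compounds named here, no measured step covers this change, and compound 1 itself is known only as a limit. Compound 3 is therefore expected to give 15000 nM, between 5000 nM and 50000 nM, most likely again as a limit. That estimate means a step that the limit leaves unreadable from compound 1 to compound 3, expected to stay within the scatter.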

Compound 3, half-maximal inhibitory concentration: 1000 nM
The estimate for compound 3 lay 15-fold (1.18 log units) above the measured number; measured number outside the range, below it.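

In this assay, hydrogen in place of hydroxy on this aromatic carbon, ortho to a methoxy group, gives an at least 10-fold lower number from compound 1 to compound 3 (1.00 log units; beyond the scatter), so the activity responds to a change at this position, which compound 1 and compound 2 could not show. The size of this step is only a lower bound, as compound 1 is known only as a limit. Compound 3 is the only compound shown that stands off that limit: the limit of > 10000 nM in this assay, at which 2 of the 3 values shown sit.

Going by these compounds, whether an amine, a fluorine or a methyl at this position would keep the number of compound 3 remains open. So does whether the same removal would have a similar effect on compound 2.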